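This account rests on a few compounds, and the source may have more. Where it says the series, first, only, none or still open, it means among the compounds named here.

Working notes on the aminochalcone series in an ADME assay on CCRF-CEM cells (Homo sapiens) for antiproliferative activity, with a stated time of 48 h; a higher number here means a weaker inhibitor, a lower number a stronger inhibitor. Compound 1 `COc1ccccc1/C=C/C(=O)c1ccc(N)cc1` gives 6300 nM in this assay. Compound 2 `COc1cccc(/C=C/C(=O)c2ccc(N)cc2)c1OC` gives 7600 nM. Compound 3 `COc1cc(/C=C/C(=O)c2ccc(N)cc2)cc(OC)c1` gives 5700 nM; the difference between the cores of compound 1 and compound 3 is not broken down here. All three numbers lie within the scatter of one another. Compound 4 `COc1cc(/C=C/C(=O)c2ccc(N)cc2)cc(OC)c1OC` is still to be measured.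

The change from compound 1 to compound 2 is methoxy in place of hydrogen on an aromatic carbon; in this assay it gave a 1.2-fold higher number from compound 1 to compound 2 (0.08 log units; within the scatter). The change from compound 3 to compound 4 is the same kind of change, (methoxy in place of hydrogen on an aromatic carbon), but its place is ortho to two methoxy groups and para to a large group, rather than ortho to a methoxy group and meta to a large group. The expectation for compound 4 is a 1.1-fold higher number from compound 3 to compound 4 (0.06 log units; within the scatter) in this assay, because a 1.2-fold higher number from compound 1 to compound 2 (0.08 log units; within the scatter) stayed within the scatter. Compound 4 is accordingly estimated at 6500 nM, in a range from 3500 nM to 13000 nM.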

Compound 4, half-maximal inhibitory concentration: 2300 nM
For compound 4 the middle estimate is 2.8-fold (0.45 log units) above the measured one; measured number below the stated range.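

In this assay, methoxy in place of hydrogen on an aromatic carbon gave a 2.5-fold lower number from compound 3 to compound 4 (0.39 log units; beyond the scatter), and the change did not carry over unchanged from one core to the other: the same change on two cores in this assay, a 1.2-fold higher number (0.08 log units; within the scatter) from compound 1 to compound 2 and a 2.5-fold lower number (0.39 log units; beyond the scatter) from compound 3 to compound 4, 3.0-fold (0.48 log units) apart, beyond the scatter of two such steps

This rests on a single pair per core, and the two pairs differ both in the core and in the place of the entering methoxy, here ortho to two methoxy groups and para to a large group; the data do not separate these two differences. Nor do they show why the steps differ, and two pairs support no general rule for this change across the series.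

From the compounds shown here alone, whether another group at that place, such as a hydroxyl or a fluorine, would match the methoxy of compound 4 remains open. Also open, going by these compounds, is whether the step holds when the amine of the shared core gives way to an amide.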